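A few compounds are considered here, and "the series" means these few. Any claim that something is new, unique, unknown or untested is made for them only; others in the source may bear on it.

Of the compounds shown here, three of the shared core have been measured so far in an ADME assay on MT4 cells (Homo sapiens) for cytotoxicity, read by MTT assay; a higher number here means that more compound is tolerated, a lower number that less compound is tolerated. Compound 1 `Cc1nc(N2Nc3onc(-c4ccccc4)c3C2c2ccc(Cl)cc2)sc1/N=N/c1ccccc1` gives 260 nM. Compound 2 `Cc1nc(N2Nc3onc(-c4ccccc4)c3C2c2ccc(Cl)cc2)sc1/N=N/c1ccc(Cl)cc1` gives 340 nM, which is the second highest of the three numbers, though its gaps to both neighbours lie within the scatter. Compound 3 `COc1ccc(/N=N/c2sc(N3Nc4onc(-c5ccccc5)c4C3c3ccc(Cl)cc3)nc2C)cc1` gives 460 nM.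

The next compound, compound 4 `Cc1nc(N2Nc3onc(-c4ccccc4)c3C2c2ccc(Cl)cc2)sc1/N=N/c1ccc([N+](=O)[O-])cc1`, arises from compound 2 by nitro in place of chloro on an aromatic carbon. The measured steps at the same aromatic carbon bear directly on this change: a 1.3-fold higher number from compound 1 to compound 2 (0.12 log units; within the scatter) and a 1.4-fold higher number from compound 2 to compound 3 (0.13 log units; within the scatter), with a 1.8-fold higher number from compound 1 to compound 3 (0.25 log units; within the scatter) spanning both. None of these steps leaves the scatter, so a substituent exchange at this position has so far not moved the readout in this assay in any direction that can be trusted. Nothing in the data suggests that a nitro group in place of chloro should behave otherwise, so no step beyond the scatter is expected in this assay , and the expected step is a 1.0-fold higher number from compound 2 to compound 4 (0.01 log units; within the scatter). Compound 4 is therefore estimated at 350 nM, with a range from 170 nM to 720 nM.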

Compound 4, half-maximal cytotoxic concentration: 280 nM
Estimate against measurement, compound 4: 1.3-fold (0.10 log units) above, and the stated range covers the measured number.
By their numbers in this assay, from the lowest: compounds 1, 4, 2 and 3 (each within the scatter of the next).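

In this assay, nitro in place of chloro stays within the scatter (a 1.2-fold lower number from compound 2 to compound 4 (0.08 log units; within the scatter)), as do nitro in place of methoxy (a 1.6-fold lower number from compound 3 to compound 4 (0.22 log units; within the scatter)) and nitro in place of hydrogen (a 1.1-fold higher number from compound 1 to compound 4 (0.03 log units; within the scatter)). Even nitro, which brings 3 heavy atoms and 2 hydrogen-bond acceptors where chloro brings 1 heavy atom and no acceptor, gives a number within the scatter of the others, so all four compounds at this position now lie within the scatter of one another and no order among them can be read. No measurement at hand offers an explanation for this result.

Going by these compounds, it remains open whether an amine, a carboxylic acid or a longer chain at this position would give a step beyond the scatter. Also open, on these data alone, is whether a change elsewhere on the shared core would do so.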